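The source may report more compounds than this note shows. Statements on the series, on what has been measured and on what is new or still open speak of the compounds shown alone.

Working notes on the series.

Compound 1 `Cc1c(C(C)C)c(=O)on1C(=O)N1CCCCC1` gives 2 nM in an assay (strain Wistar) for inhibition of Hormone-sensitive lipase (Rattus norvegicus), read by spectrophotometry; a lower number here means a stronger inhibitor, a higher number a weaker inhibitor. Among the compounds with values here, compound 2 `Cc1c(C2CCCC2)c(=O)on1C(=O)N1CCCCC1` gives 6 nM in this assay; on the two numbers known so far, compound 2 stands at the higher of the two, with compound 1 the nearest point, set apart by a 3.0-fold higher number from compound 1 to compound 2 (0.48 log units; beyond the scatter). The next compound in the line is compound 3 `Cc1c(C2CCOCC2)c(=O)on1C(=O)N1CCCCC1`, which differs from compound 2 only by oxan-4-yl in place of cyclopentyl on an aromatic carbon. Within the data shown here, the single step measured so far, a 3.0-fold higher number from compound 1 to compound 2 (0.48 log units; beyond the scatter), is the only one that bears on this change, and it concerns the neighbouring ring size rather than the ring heteroatom, so its guidance is limited. No comparison of a carbocyclic ring against a ring with one oxygen is available. On that basis, the change from compound 2 to compound 3 is expected to give at most a small step, a 1.7-fold higher number from compound 2 to compound 3 (0.22 log units; within the scatter), which would lie within the scatter. Compound 3 is therefore estimated at 10 nM, with a range from 3 nM to 40 nM.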

Compound 3, half-maximal inhibitory concentration: 71 nM
Estimate against measurement, compound 3: 7.1-fold (0.85 log units) below; the measured number lies above the stated range.
By their numbers in this assay, from the lowest: compound 1; then compound 2; then compound 3.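

In this assay, the position on the aromatic carbon responds far more strongly to this change than to the earlier one: oxan-4-yl in place of cyclopentyl gives a 12-fold higher number from compound 2 to compound 3 (1.07 log units; beyond the scatter), against a 3.0-fold higher number from compound 1 to compound 2 (0.48 log units; beyond the scatter) for cyclopentyl in place of isopropyl. Measured from the isopropyl group, the overall step is a 36-fold higher number from compound 1 to compound 3 (1.55 log units; beyond the scatter), so a ring at this position is not interchangeable with the other groups here, and the three compounds are clearly separated in this assay. Nothing available explains the size of the step.

The change from compound 2 to compound 3 alters ring size and introduces the ring oxygen together, and the compounds shown cannot separate the two. A cyclohexyl group at this position would divide them, and a piperidin-4-yl group would test a ring nitrogen in place of that oxygen.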